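Difluorophenyl swap on the tolyl thiocarbamate core

The source may hold more compounds than are shown below. What is called first, only, known or untested is meant among the compounds shown, and "the series" means these compounds.

Three members of the series have cytotoxicity numbers. Compound 1 `O=C1c2ccccc2C(=O)N1CCOC(=S)N(C(=O)c1ccc(F)cc1F)c1ccc(Cl)cc1` gives 52000 nM in an ADME assay on MT4 cells (Homo sapiens) for cytotoxicity, read by MTT assay; a lower number here means that less compound is tolerated, a higher number that more compound is tolerated. Compound 2 `O=C1c2ccccc2C(=O)N1CCOC(=S)N(C(=O)c1cc(F)ccc1F)c1ccc(Cl)cc1` gives 54000 nM in this assay. Compound 3 `Cc1ccc(N(C(=O)c2ccc(F)cc2F)C(=S)OCCN2C(=O)c3ccccc3C2=O)cc1` gives 20000 nM in this assay, the lowest of the three numbers.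

Two single changes connect them. Moving 2,5-difluorophenyl in place of 2,4-difluorophenyl on a carbonyl carbon left the number essentially where it was: a 1.0-fold higher number from compound 1 to compound 2 (0.02 log units; within the scatter). Moving methyl in place of chloro on an aromatic carbon gave a modest drop: a 2.6-fold lower number from compound 1 to compound 3 (0.41 log units; beyond the scatter).

Compound 4 `Cc1ccc(N(C(=O)c2cc(F)ccc2F)C(=S)OCCN2C(=O)c3ccccc3C2=O)cc1` has not yet been measured. It differs from compound 3 by 2,5-difluorophenyl in place of 2,4-difluorophenyl on a carbonyl carbon. Within the data shown here, this is the same change as the one between compound 1 and compound 2, made on a core that differs from theirs by methyl in place of chloro on an aromatic carbon. The change occurs twice in all among the compounds shown, and the one measured instance stayed within the scatter.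

The expectation for compound 4 in this assay therefore rests on that single precedent: a step of about a 1.1-fold higher number from compound 3 to compound 4 (0.02 log units; within the scatter) is expected from compound 3 to compound 4, because a 1.0-fold higher number from compound 1 to compound 2 (0.02 log units; within the scatter) showed that this repositioning of fluorine did not shift the number on the chloro core. From the compounds shown here alone, whether the methyl core behaves alike is untested, so the range is kept wide. Compound 4 is estimated at 21000 nM, with the likely span running from 10000 nM to 42000 nM.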

Compound 4, half-maximal cytotoxic concentration: 62000 nM
The estimate for compound 4 lay 3.0-fold (0.47 log units) below the measured number, outside the stated range (above it).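

In this assay, 2,5-difluorophenyl in place of 2,4-difluorophenyl on a carbonyl carbon gives a 3.1-fold higher number from compound 3 to compound 4 (0.49 log units; beyond the scatter), so this change does not carry unchanged from one core to the other: the same change on two cores in this assay, a 1.0-fold higher number (0.02 log units; within the scatter) from compound 1 to compound 2 and a 3.1-fold higher number (0.49 log units; beyond the scatter) from compound 3 to compound 4, 3.0-fold (0.47 log units) apart, beyond the scatter of two such steps. Methyl in place of chloro on an aromatic carbon likewise depends on its partner, giving a 1.1-fold higher number from compound 2 to compound 4 (0.06 log units; within the scatter) with 2,5-difluorophenyl present, unlike the drop seen with 2,4-difluorophenyl: the same change on two cores in this assay, a 2.6-fold lower number (0.41 log units; beyond the scatter) from compound 1 to compound 3 and a 1.1-fold higher number (0.06 log units; within the scatter) from compound 2 to compound 4, 3.0-fold (0.47 log units) apart, beyond the scatter of two such steps. Among these compounds, the two changes therefore do not add independently across these four compounds, with compound 3 holding the one low number, but this single set of four shows neither why that is nor whether the same dependence would appear on any other core.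

From the compounds shown here alone, it remains open whether the dependence extends to other groups in the same places, such as an unsubstituted phenyl on the carbonyl carbon or a trifluoromethyl or methoxy group in place of chloro or methyl. Going by these compounds, it is also open whether a repeat determination of compound 3 would hold its number, since the whole departure from a simple transfer rests on that one compound.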